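The source may report more compounds than this note shows. Statements on the series, on what has been measured and on what is new or still open speak of the compounds shown alone.

Values in a functional assay (aorta) with Oryctolagus cuniculus as the target; on this read-out lower numbers stand for stronger inhibition and higher numbers for weaker inhibition:

- compound 1 `CC1=C(C)C(=O)C(C(CCCCCC(=O)O)c2ccc(C)cc2)=C(C)C1=O`: 1000 nM
- compound 2 `CC1=C(C)C(=O)C(C(CCCCCC(=O)O)c2cccc(F)c2)=C(C)C1=O`: 1900 nM
- compound 3 `CC1=C(C)C(=O)C(C(CCCCCC(=O)O)c2ccc(Cl)cc2)=C(C)C1=O`: 280 nM

Among these three, compound 3 has the lowest number, and its steps to both of the others lie beyond the scatter. The next structure, compound 4 `CC1=C(C)C(=O)C(C(CCCCCC(=O)O)c2ccc(Br)cc2)=C(C)C1=O`, has not yet been measured in this assay. It differs from compound 3 by bromo in place of chloro on an aromatic carbon, which is bromo in place of chloro on an aromatic carbon.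

Among the compounds with values here, no measured step makes this exchange, so the evidence is indirect. Two steps arrive at the chloro group of compound 3 from other substituents: a 3.6-fold lower number from compound 1 to compound 3 (0.55 log units; beyond the scatter), and a 6.8-fold lower number from compound 2 to compound 3 (0.83 log units; beyond the scatter). Both are modest, and the second also changes the 3-fluorophenyl group to 4-chlorophenyl. They show that this substituent can shift the number, but neither tests bromo. A swap of chloro for bromo at the same place is therefore expected to produce little change. The expected step is a 1.1-fold lower number from compound 3 to compound 4 (0.05 log units; within the scatter), with no shift beyond the scatter anticipated. For compound 4 the estimated value is 250 nM, within an expected range of 110 nM to 600 nM.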

Compound 4, half-maximal inhibitory concentration: 1700 nM
Compound 4: the middle estimate sits 6.8-fold (0.83 log units) below what was measured; the whole stated range lies below it.
By their numbers in this assay, from the lowest: compound 3; then compounds 1, 4 and 2 (each within the scatter of the next).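

At this place, para to a large group, chloro and bromo are not interchangeable in this assay: the exchange gives a 6.1-fold higher number from compound 3 to compound 4 (0.78 log units; beyond the scatter), so the low number of compound 3 does not carry over to the 4-bromophenyl group. Bromo instead leaves the number level with the other two substituents, with a 1.7-fold higher number from compound 1 to compound 4 (0.23 log units; within the scatter) and a 1.1-fold lower number from compound 2 to compound 4 (0.05 log units; within the scatter), and among these four compounds only the chloro group of compound 3 stands apart. No measurement offered here accounts for this difference between chloro and bromo.

The compounds shown leave open whether the low number is particular to chloro or could also be reached with iodo or methoxy at the same place. They also leave open how a 3-chlorophenyl group would compare with the 4-chlorophenyl group of compound 3.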